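Trifluoromethyl for Methyl on a Second Hydrazone Core

A few compounds are considered here, and "the series" means these few. Any claim that something is new, unique, unknown or untested is made for them only; others in the source may bear on it.

Measured in a functional assay, read by spectrophotometry, with a stated time of 2 h; a higher number here means a weaker inhibitor, a lower number a stronger inhibitor:
compound 1, `CCOC(=O)N1CCC(=NNC(=O)c2ccc(C)cc2)CC1`, gives 75500 nM;
compound 2, `CCOC(=O)N1CCC(=NNC(=O)c2ccc(C(F)(F)F)cc2)CC1`, gives 33800 nM;
compound 3, `Cc1ccc(C(=O)NN=C2CC(c3ccccc3)NC(c3ccccc3)C2)cc1`, gives 53300 nM.

Compound 1 and compound 2 share one core, and compound 3 sits on another; the difference between the two cores is not broken down here. Compound 1 and compound 2 differ by trifluoromethyl in place of methyl on an aromatic carbon. This change gave a 2.2-fold lower number from compound 1 to compound 2 (0.35 log units; beyond the scatter). Compound 4, `O=C(NN=C1CC(c2ccccc2)NC(c2ccccc2)C1)c1ccc(C(F)(F)F)cc1`, has not yet been measured. It carries the same change on the core of compound 3, (trifluoromethyl in place of methyl on an aromatic carbon), and the place of the change is the same in both pairs. Resting on the measured step of a 2.2-fold lower number from compound 1 to compound 2 (0.35 log units; beyond the scatter), the step expected for compound 4 is a 2.1-fold lower number from compound 3 to compound 4 (0.33 log units; beyond the scatter). Compound 4 is therefore estimated at 25000 nM in this assay, with a likely range from 10000 nM to 60000 nM.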

Compound 4, half-maximal inhibitory concentration: 65000 nM
Compound 4: middle estimate off by 2.6-fold (0.41 log units), on the low side; the whole stated range lies below it.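

In this assay trifluoromethyl in place of methyl gave a 1.2-fold higher number from compound 3 to compound 4 (0.09 log units; within the scatter) and so no difference that stands clear of the usual scatter on this core. Set beside the earlier step, the same change did not act alike on the two cores: the same change on two cores in this assay, a 2.2-fold lower number (0.35 log units; beyond the scatter) from compound 1 to compound 2 and a 1.2-fold higher number (0.09 log units; within the scatter) from compound 3 to compound 4, 2.7-fold (0.44 log units) apart, beyond the scatter of two such steps. The lower number seen on the core of compound 1 therefore did not carry over to the core of compound 3, but with a single pair on each core this does not show why, nor how any further core would respond.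

The compounds shown leave open whether another group on the same aromatic carbon, such as a nitrile, an amine or a carboxylic acid, would also act differently on the two cores.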